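A Cyano Group Enters Where a Methyl Stood

The source may hold more compounds than are shown below. What is called first, only, known or untested is meant among the compounds shown, and "the series" means these compounds.

Compound 3 `Cc1ccc(-c2nc3c(c(C)nn3-c3ccccc3)c(-c3ccccc3O)c2C#N)cc1` belongs to a set of three measured in a physicochemical assay for solubility, read by spectrophotometry, in phosphate buffer, with a stated time of 18 h, at pH 7.4 (on this read-out higher numbers stand for higher solubility and lower numbers for lower solubility), where compound 3 gives 26000 nM. Compound 2 `CCc1ccc(-c2nc3c(c(C)nn3-c3ccccc3)c(-c3ccccc3)c2C#N)cc1` gives 47000 nM, and compound 1 `CCc1ccc(-c2nc3c(c(C)nn3-c3ccccc3)c(-c3ccccc3C)c2C#N)cc1` gives 6000 nM. Compound 3 is thus second highest of the three: its gap to compound 2 is within the scatter, while its gap to compound 1 is beyond it. Compound 4 `Cc1nn(-c2ccccc2)c2nc(-c3ccc(C#N)cc3)c(C#N)c(-c3ccccc3O)c12` differs from compound 3 in one place: cyano in place of methyl on an aromatic carbon That is, 4-methylphenyl becomes 4-cyanophenyl, at a position para to a large group. Within the data shown here, no measured step puts a cyano group in. Among the measured compounds shown here, the only step in the set, a 7.8-fold higher number from compound 1 to compound 2 (0.89 log units; beyond the scatter), shows that taking a methyl off an aromatic carbon raised the number, and it bears on the present change only loosely, since here a cyano group enters where the methyl left. A small to modest rise, near the edge of the scatter, is therefore expected: a 1.5-fold higher number from compound 3 to compound 4 (0.19 log units; within the scatter). Compound 4 is estimated at 40000 nM, within a range from 15000 nM to 110000 nM.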

Compound 4, solubility: 1700 nM
Compound 4: middle estimate off by 24-fold (1.37 log units), on the high side; measured number outside the range, below it.
By their numbers in this assay, from the lowest: compound 4; then compound 1; then compounds 3 and 2 (each within the scatter of the next).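

The change from 4-methylphenyl to 4-cyanophenyl, para to a large group, brought a 15-fold lower number from compound 3 to compound 4 (1.18 log units; beyond the scatter), so in this assay this position responds strongly to what stands on it. Among these compounds, the only earlier step, a 7.8-fold higher number from compound 1 to compound 2 (0.89 log units; beyond the scatter), came from a methyl leaving another place on the core and ran the opposite way, so it could not show that a change at this position would lower the number so sharply. Nothing at hand speaks to why the number fell.

The compounds shown leave open whether the fall follows from the methyl leaving or from the cyano group entering. They also leave open how an amine or a carboxylic acid on the same aromatic carbon would read in this assay.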